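Replacing a Methylamino Arm with a Larger Ring-Bearing Group

The source may report more compounds than this note shows. Statements on the series, on what has been measured and on what is new or still open speak of the compounds shown alone.

Measured compounds:
- Compound 1, `CN(Cc1cc(C(F)(F)F)cc(C(F)(F)F)c1)C(=O)c1c(CBr)nc2ccccc2c1-c1ccccc1`, 52 nM
- Compound 2, `CN(Cc1cc(C(F)(F)F)cc(C(F)(F)F)c1)C(=O)c1c(CN)nc2ccccc2c1-c1ccccc1`, 9 nM
- Compound 3, `CNCc1nc2ccccc2c(-c2ccccc2)c1C(=O)NCc1cc(C(F)(F)F)cc(C(F)(F)F)c1`, 0.011 nM

All three were tested in an in vitro assay on UC11MG cells for binding affinity to Substance-P receptor (Homo sapiens), read by radioligand binding; a lower number here means a stronger inhibitor, a higher number a weaker inhibitor. Compound 3 gives the lowest number of the three measured compounds, with compound 2 nearest and compound 1 furthest from it. Among the compounds with values here, the only step between compounds that differ in one place is a 5.8-fold lower number from compound 1 to compound 2 (0.76 log units; beyond the scatter), a modest change. Compound 4, `O=C(NCc1cc(C(F)(F)F)cc(C(F)(F)F)c1)c1c(CN2C(=O)c3ccccc3C2=O)nc2ccccc2c1-c1ccccc1`, has not yet been measured in this assay. It differs from compound 3 by a group of 11 heavy atoms (8 carbon, 1 nitrogen, 2 oxygen; one five-membered non-aromatic ring with 1 hetero atom, one six-membered aromatic ring of carbon only) in place of a group of 2 heavy atoms (1 carbon, 1 nitrogen; no ring), on a saturated chain carbon bound to an aromatic carbon. Within the data shown here, no measured step covers a change of this kind; the step from compound 1 to compound 2 concerns the same place but a different exchange, and the gap between compound 2 and compound 3 spans two changes at once. The data do show that compound 3, carrying methylamino, sits far below compound 2 and compound 1. Compound 4 is therefore expected to give a higher number than compound 3, with the step estimated as a 270-fold higher number from compound 3 to compound 4 (2.44 log units; beyond the scatter). The estimate for compound 4 in this assay is 3 nM, within a range from 0.2 nM to 50 nM.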

Compound 4, half-maximal inhibitory concentration: > 1000 nM
Compound 4 was reported as a limit; the forecaster's own chance of this, stated with the estimate: 5%; at least 330-fold (2.52 log units) between middle value and limit.
By their numbers in this assay, from the lowest: compound 3; then compound 2; then compound 1. At a limit, above all of these: compound 4.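

In this assay compound 4 gives > 1000 nM as a limit and not as a number: the limit of > 1000 nM in this assay, at which 1 of the 4 values shown sits.

Placing the group of 11 heavy atoms, with its five-membered non-aromatic ring and six-membered aromatic ring, on the saturated chain carbon in place of methylamino gives an at least 90000-fold higher number from compound 3 to compound 4 (4.95 log units; beyond the scatter) and so shows that this position does not accept every exchange with little loss. Within the data shown here, the only earlier exchange at this place, a 5.8-fold lower number from compound 1 to compound 2 (0.76 log units; beyond the scatter), was modest by comparison.

The compounds shown leave open whether a smaller ring-bearing amine such as piperidine, or an acetamide on the same carbon, would stay near compound 3. They also cannot separate the effect of the two rings from that of the two carbonyl groups or of losing the hydrogen-bond donor.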